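Trifluoromethyl on the anilino ring of compound 1

This account rests on a few compounds, and the source may have more. Where it says the series, first, only, none or still open, it means among the compounds named here.

Compound 1 `c1ccc(Nc2ccc(N3CC4CC(C3)N4)cn2)cc1` stands lowest of the two numbers measured in an assay on cell membranes for displacement of a labelled ligand from Neuronal acetylcholine receptor; alpha4/beta2 (Rattus norvegicus); a higher number here means a weaker inhibitor, a lower number a stronger inhibitor; in this assay compound 1 gives 2.66 nM. Compound 2 `Clc1cccc(Nc2ccc(N3CC4CC(C3)N4)nn2)c1`, which differs from it in its core as well as on its phenyl ring, gives 1540 nM in this assay, a gap far beyond the scatter. Compound 3 `FC(F)(F)c1ccc(Nc2ccc(N3CC4CC(C3)N4)cn2)cc1` carries trifluoromethyl in place of hydrogen on an aromatic carbon. Going by the values given here, no single-change step is known, so the size of the change is open; a modest loss is expected, a 3.8-fold higher number from compound 1 to compound 3 (0.58 log units; beyond the scatter). For compound 3 the expected value in this assay is 10 nM, within 2 nM to 60 nM.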

Compound 3, inhibition constant: 0.569 nM
Compound 3: the middle estimate sits 18-fold (1.24 log units) above what was measured, outside the stated range (below it).
By their numbers in this assay, from the lowest: compound 3; then compound 1; then compound 2.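

On an aromatic carbon para to a large group, trifluoromethyl in place of hydrogen is the only single-place change shown, and in this assay it gives a 4.7-fold lower number from compound 1 to compound 3 (0.67 log units; beyond the scatter), so this position accepts the larger group with a modest gain rather than a loss. Nothing measured here accounts for that gain. As far as these compounds go, whether the gain is particular to trifluoromethyl remains open, since an amine, a carboxylic acid or a methoxy group on the same carbon would test this. Also open, from the compounds shown here alone, is whether the same change would help on the core of compound 2.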